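Swapping chloro for methoxy on a weakly active series

This account rests on a few compounds, and the source may have more. Where it says the series, first, only, none or still open, it means among the compounds named here.

Measured in an assay on isolated protein for inhibition of DNA nucleotidylexotransferase (Homo sapiens), read by scintillation counting, with a stated time of 10 min; on this read-out higher numbers stand for weaker inhibition and lower numbers for stronger inhibition:
- Compound 1 `CCOC(=O)C(=O)CC(=O)/C=C/c1cn(-c2ccccc2)c2ccccc12` gives > 40 uM, a limit of the assay.
- Compound 2 `CCOC(=O)C(=O)CC(=O)/C=C/c1cn(-c2ccc(Cl)cc2)c2ccccc12` gives > 40 uM, also a limit.
- Compound 3 `CCOC(=O)C(=O)CC(=O)/C=C/c1cn(Cc2ccc(Cl)cc2)c2ccccc12` gives 40 uM.

Among the measured compounds shown here, compound 3 holds the only real number among the three results; the other two values sit at the limit of > 40 uM in this assay, at which 2 of the 3 values shown sit. For the measured compounds named here, because of the limit of > 40 uM in this assay, at which 2 of the 3 values shown sit, the step that the two limits leave unreadable from compound 1 to compound 2 cannot be read, and the steps of a number no higher from compound 1 to compound 3 (the limit leaves the size open) and a number no higher from compound 2 to compound 3 (the limit leaves the size open) tell only that the number did not rise, with their size left open.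

Compound 4 `CCOC(=O)C(=O)CC(=O)/C=C/c1cn(Cc2ccc(OC)cc2)c2ccccc12` differs from compound 3 in one place: methoxy in place of chloro on an aromatic carbon. Going by the values given here, no measured step touches this kind of change, and the steps that do exist carry no readable size, so they give no ground for expecting a move beyond the scatter of this assay in either direction. The estimate for compound 4 therefore rests on the single number shown for compound 3 and sits close to the limit, where the assay may again report only a limit. Compound 4 is expected to give about 45 uM, with a range from 15 uM to 120 uM, an expected step of a 1.1-fold higher number from compound 3 to compound 4 (0.05 log units; within the scatter).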

Compound 4, concentration for 50% inhibition: > 40 uM
Compound 4 ended at the assay's limit; the forecaster's own chance of this, stated with the estimate: 55%; the middle value lies beyond the limit too.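

Methoxy in place of chloro on this aromatic carbon gives a number no lower from compound 3 to compound 4 (the limit leaves the size open) in this assay, the first reading of any change at this place. Among the compounds shown here, the swap brings in one more heavy atom and one hydrogen-bond acceptor, and neither turned into a lower number, so compound 3 remains the only compound here with a measured value rather than a limit. The steps from compound 1 and compound 2 to compound 4 cannot be read, because both ends of each step sit at the same limit: the limit of > 40 uM in this assay, at which 3 of the 4 values shown sit.

The size of the step from compound 3 leaves open how far compound 4 lies past the limit, and so whether it differs from compound 3 by more than the usual scatter. The compounds shown also leave open whether an amine or a carboxylic acid at this place would give a lower number than chloro or methoxy.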